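Triazole aryl variation in the allylphenol series

This account rests on a few compounds, and the source may have more. Where it says the series, first, only, none or still open, it means among the compounds named here.

In a functional assay on SK-N-SH cells (Homo sapiens) for inhibition, read by MTT assay, with a stated time of 72 h, tested at 30 uM (a lower number here means less inhibition of growth, a higher number more inhibition of growth at the concentration tested), compound 1 `C=CCc1ccc(OCc2cn(-c3ccccc3CO)nn2)c(O)c1` gives 12.9%. Compound 2 `C=CCc1ccc(OCc2cn(-c3ccccc3Cl)nn2)c(O)c1` gives 10.2%, the lowest of the three numbers; the step of a number 2.7 percentage points lower from compound 1 to compound 2 (within the scatter) shows that chloro in place of hydroxymethyl on an aromatic carbon leaves the read-out unchanged within the scatter. Going by the values given here, compound 3 `C=CCc1cc(O)c(O)c(CN2CCC(Cc3ccccc3)CC2)c1`, built on another core without the triazole, gives 78.8%, a number far beyond the scatter from compound 2; no single-point step links it to compound 2, so its number only shows how wide the series spreads.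

Compound 4 `C=CCc1ccc(OCc2cn(-c3cccc(C#N)c3)nn2)c(O)c1` carries 3-cyanophenyl in place of 2-chlorophenyl on an aromatic nitrogen. Among the compounds with values here, the only measured step that bears on this change is the aryl swap on the same ring nitrogen, a number 2.7 percentage points lower from compound 1 to compound 2 (within the scatter), which stayed within the scatter; compound 3 shares no comparable change. Another aryl group on that ring nitrogen is therefore expected to give no step beyond the scatter in this assay, the estimated step being a number 1.8 percentage points higher from compound 2 to compound 4 (within the scatter). For compound 4 the expected value is 12%, within 3% to 25%.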

Compound 4, percent growth inhibition at one concentration: 21.2%
The estimate for compound 4 lay 9.2 percentage points below the measured number, within the range that was stated.
By their numbers in this assay, from the lowest: compounds 2, 1 and 4 (each within the scatter of the next, the first and the last beyond it); then compound 3.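

In this assay, exchanging the aryl group on the aromatic nitrogen can move the read-out beyond the scatter, as 3-cyanophenyl in place of 2-chlorophenyl gives a number 11 percentage points higher from compound 2 to compound 4 (beyond the scatter) and the earlier exchange on this nitrogen did not. Against 2-(hydroxymethyl)phenyl, the same group gives a number 8.3 percentage points higher from compound 1 to compound 4 (within the scatter), so the separation holds against 2-chlorophenyl only and does not yet mark 3-cyanophenyl as distinct from both earlier aryl groups. No measurement at hand accounts for this step.

The exchange alters both the substituent and its place on the phenyl ring, and the compounds shown do not separate these two changes. Also open, going by these compounds, is how an aminophenyl or a carboxyphenyl group on the same ring nitrogen would read in this assay series.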